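The compounds below may be only part of what the source reports. "The series", "measured", "known", "first", "only" and "open" are said of these compounds alone.

Of the compounds shown here, two with a shared core have been measured so far. In a physicochemical assay for solubility, using the shake flask method, in phosphate buffer, at pH 7 (a lower number here means a less soluble compound, a higher number a more soluble compound), compound 1 (`COc1ncc(-c2ccc(C(=O)O)cc2C)cc1-c1cc(C(F)(F)F)c(OC)nc1CN1C(=O)O[C@H](c2cc(C(F)(F)F)cc(C(F)(F)F)c2)[C@@H]1C`) gives 5000 nM, and compound 2 (`COc1ccc(-c2ccc(C(=O)O)cc2C)cc1-c1cnc(C(C)(F)F)nc1CN1C(=O)O[C@H](c2cc(C(F)(F)F)cc(C(F)(F)F)c2)[C@@H]1C`) gives 20000 nM. Compound 2 therefore holds the higher of the two numbers, and its gap to compound 1 lies beyond the usual scatter of repeated measurements. Compound 3 (`COc1ncc(-c2cc(-c3ccc(C(=O)O)cc3C)ccc2OC)c(CN2C(=O)O[C@H](c3cc(C(F)(F)F)cc(C(F)(F)F)c3)[C@@H]2C)n1`) carries methoxy in place of 1,1-difluoroethyl on an aromatic carbon, between two ring nitrogen atoms (methoxy in place of 1,1-difluoroethyl on an aromatic carbon). Going by the values given here, no measured pair shows this change on its own, so any forecast is a judgement. The expected step in this assay is small, a 1.4-fold lower number from compound 2 to compound 3 (0.15 log units; within the scatter), and is estimated to stay within the scatter. The lower number of compound 1, 5000 nM, keeps the low end of the range open. For compound 3 the estimated value is 14000 nM, with an expected range of 4000 nM to 40000 nM.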

Compound 3, solubility: 52000 nM
Compound 3: middle estimate off by 3.7-fold (0.57 log units), on the low side; measured number above the stated range.
By their numbers in this assay, from the lowest: compound 1; then compound 2; then compound 3.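

In this assay, the aromatic carbon between two ring nitrogen atoms now has its first direct reading: methoxy in place of 1,1-difluoroethyl gives a 2.6-fold higher number from compound 2 to compound 3 (0.41 log units; beyond the scatter) and this modest step lies beyond the scatter. A change at this one position is therefore enough to move the number, here towards the more soluble end of the assay. The group that leaves has 4 heavy atoms and 0 hydrogen-bond acceptors, while the group that enters has 2 heavy atoms and 1 hydrogen-bond acceptor, but no measurement at hand explains the step.

This single pair cannot separate the effect of gaining methoxy from that of losing 1,1-difluoroethyl. An amine, a hydroxyl group or a longer chain on the same carbon would help to tell the two apart.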